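A few compounds are considered here, and "the series" means these few. Any claim that something is new, unique, unknown or untested is made for them only; others in the source may bear on it.

Compound 1 `c1ccc(Cn2c(-c3nc4ccccc4[nH]3)cc3ccccc32)cc1` and compound 2 `Clc1cc2nc(-c3cc4ccccc4n3Cc3ccccc3)[nH]c2cc1Cl` share a benzyl group on an aromatic nitrogen; the difference between their two cores is not broken down here. In a functional assay on T47D cells (Homo sapiens) for antiproliferative activity, read by MTT assay, with a stated time of 48 h (a lower number here means a stronger inhibitor, a higher number a weaker inhibitor), compound 1 gives 21500 nM, and compound 2 gives 22500 nM. Compound 3 `c1ccc2[nH]c(-c3nc4ccccc4[nH]3)cc2c1` is compound 1 with hydrogen in place of benzyl on an aromatic nitrogen, and in this assay compound 3 gives 6200 nM, so a 3.5-fold lower number from compound 1 to compound 3 (0.54 log units; beyond the scatter). Compound 4 `Clc1cc2nc(-c3cc4ccccc4[nH]3)[nH]c2cc1Cl` stands to compound 2 as compound 3 stands to compound 1, through (hydrogen in place of benzyl on an aromatic nitrogen); the neighbouring ring atom bears a large group in one case and a group of 9 heavy atoms in the other, so this is the same kind of change rather than the same change. Because the earlier step gave a 3.5-fold lower number from compound 1 to compound 3 (0.54 log units; beyond the scatter), the expected step is a 3.5-fold lower number from compound 2 to compound 4 (0.54 log units; beyond the scatter). For compound 4 the estimate is 6500 nM, between 3000 nM and 15000 nM.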

Compound 4, half-maximal inhibitory concentration: 21200 nM
Compound 4: the middle estimate sits 3.3-fold (0.51 log units) below what was measured, and the stated range ends below it.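

In this assay, putting hydrogen in place of benzyl on the aromatic nitrogen gives a 1.1-fold lower number from compound 2 to compound 4 (0.03 log units; within the scatter), so the change that mattered on the core of compound 1 leaves no clear mark on the core of compound 2. The same change therefore does not carry over at the same size from one core to the other: the same change on two cores in this assay, a 3.5-fold lower number (0.54 log units; beyond the scatter) from compound 1 to compound 3 and a 1.1-fold lower number (0.03 log units; within the scatter) from compound 2 to compound 4, 3.3-fold (0.51 log units) apart, beyond the scatter of two such steps. Among the compounds shown here, these two steps show only that a step measured on one of these cores cannot be assumed on the other; they do not show which part of the cores makes the difference, or how the change would behave on a further core. The compounds shown leave open whether a different group on that nitrogen, such as methyl or a longer chain ending in an amine, would also give steps that differ between the two cores.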